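Replacing the Pyrrolidine Acid with Glycine in Tail Flick

The source may hold more compounds than are shown below. What is called first, only, known or untested is meant among the compounds shown, and "the series" means these compounds.

Compound 1 `O=C(O)[C@@H]1CCCN1C(=O)CN(c1nc(Cl)nc2[nH]cnc12)C1CC1` was tested in a functional assay on the whole organism (Tail, strain ICR) with Mus musculus as the target, in the tail flick test, with a stated time of 90 min, at a dose of 25 umol/kg by the oral route (a lower number here means a weaker effect, a higher number a stronger effect of the compound at the dose given), and gave 26%, the lower of the two numbers recorded so far. Compound 2 `CC(C)C[C@H](NC(=O)CN(c1ncnc2c1ncn2C1CCCCO1)C1CC1)C(=O)OCc1ccccc1` gives 28.2% in this assay; the two values lie within the scatter of each other, so no order between them can be claimed. Compound 3 `O=C(O)CNC(=O)CN(c1nc(Cl)nc2[nH]cnc12)C1CC1` has not yet been measured. It differs from compound 1 by (carboxymethyl)amino in place of 2-carboxypyrrolidin-1-yl on a carbonyl carbon. Among the measured compounds shown here, no measured pair shows this change, so the data give no direction for it. Compound 3 is therefore expected to give about 25% in this assay, between 10% and 42%. The expected step of a number 1 percentage points lower from compound 1 to compound 3 (within the scatter) stays within the scatter.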

Compound 3, a percentage reported as activity, at one dose (the size of the read-out at that dose, not a potency): 32.3%
Compound 3: the middle estimate sits 7.3 percentage points below what was measured; measured number inside the range.
By their numbers in this assay, from the lowest: compounds 1, 2 and 3 (each within the scatter of the next).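

In this assay, (carboxymethyl)amino in place of 2-carboxypyrrolidin-1-yl on a carbonyl carbon gives the first step read at this position (a number 6.3 percentage points higher from compound 1 to compound 3 (within the scatter)). Losing the five-membered ring and the defined stereocentre of the group that leaves therefore produces no difference that this assay can separate at this dose. Nothing measured on these compounds offers an explanation for this reading. Still open, going by these compounds, is whether a longer chain carrying the carboxylic acid, or a primary amide in its place, on this carbonyl carbon would move the read-out beyond the scatter.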